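Benzyl ether variation on the pyridyl benzamide series

A few compounds are considered here, and "the series" means these few. Any claim that something is new, unique, unknown or untested is made for them only; others in the source may bear on it.

Compound 1 `O=C(Nc1cccnc1)c1ccccc1OCc1ccccc1` carries an unsubstituted benzyl ether on the shared core and in an assay on lysate for inhibition of phosphatidylcholine:ceramide cholinephosphotransferase 2 (Homo sapiens), read by HPLC, with stated times of 30 min and 2 h (a higher number here means a weaker inhibitor, a lower number a stronger inhibitor), compound 1 gives 3200 nM. Compound 2 `N#Cc1cccc(COc2ccccc2C(=O)Nc2cccnc2)c1` adds a nitrile to the benzyl ring, and in this assay compound 2 gives 60700 nM. Among the compounds with values here, compound 2 therefore stands at the highest of the two numbers measured so far, its only neighbour being compound 1, reached by the step of a 19-fold higher number from compound 1 to compound 2 (1.28 log units; beyond the scatter).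

Compound 3 `O=C(Nc1cccnc1)c1ccccc1OCc1c(F)cccc1Cl` has not been measured. It differs from compound 2 in one place: 2-chloro-6-fluorophenyl in place of 3-cyanophenyl on a saturated chain carbon bound to an oxygen on an aromatic ring. Within the data shown here, no measured pair shows the entering halogenated ring, so the only step that bears on this change is a 19-fold higher number from compound 1 to compound 2 (1.28 log units; beyond the scatter), and compound 3 reverses the part of that step that the nitrile contributed while adding two halogens whose effect is untested here. The expected direction is a lower number than compound 2, of a size comparable to that single step, with a wide range because of the untested halogens. The estimate for compound 3 in this assay is 2500 nM, between 400 nM and 15000 nM, which means the expected step of a 24-fold lower number from compound 2 to compound 3 (1.39 log units; beyond the scatter).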

Compound 3, half-maximal inhibitory concentration: 1500 nM
Beside the measured number, compound 3's estimate is 1.7-fold (0.22 log units) above it; low and high end bracket the measured number.
By their numbers in this assay, from the lowest: compound 3; then compound 1; then compound 2.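

On the saturated chain carbon bound to an oxygen on an aromatic ring, substitution on the ring does not always raise the number: in this assay the step of a 2.1-fold lower number from compound 1 to compound 3 (0.33 log units; beyond the scatter) with 2-chloro-6-fluorophenyl runs opposite to the one earlier substituted ring, 3-cyanophenyl. The direct exchange of the two substituted rings gives a 40-fold lower number from compound 2 to compound 3 (1.61 log units; beyond the scatter) and is far larger than the gain over phenyl, so most of its size matches what 3-cyanophenyl had lost against phenyl, and little of it is a gain over phenyl itself. No measurement at hand explains either step.

The chlorine and the fluorine enter together, so these compounds cannot separate what each contributes, nor show whether a single halogen would keep the lower number. Also open, as far as these compounds go, is whether this place tolerates an amine or a carboxylic acid on the ring, or a longer chain in place of the present link to it.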